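The source may report more compounds than this note shows. Statements on the series, on what has been measured and on what is new or still open speak of the compounds shown alone.

Of the compounds shown here, three with a shared core have so far been tested in an assay on isolated protein for inhibition of protein deacetylase HDAC6 (Homo sapiens), read by fluorescence, with stated times of 3 h and 60 min; on this read-out higher numbers stand for weaker inhibition and lower numbers for stronger inhibition. Compound 1, `COc1ccc(NC(=O)c2ccc(CNc3nccc(-c4cccnc4)n3)cc2)c(N)c1`, returns only a limit of the assay, > 20000 nM. Compound 2, `CC(C)(C)[Si](C)(C)OCc1ccc(NC(=O)c2ccc(CNc3nccc(-c4cccnc4)n3)cc2)c(N)c1`, likewise gives no number but the limit > 20000 nM. Compound 3, `Nc1cc2ccccc2cc1NC(=O)c1ccc(CNc2nccc(-c3cccnc3)n2)cc1`, also sits at the limit, > 20000 nM, so its standing among the three cannot be placed on a scale; all that is known is that it is not potent enough to be read, and that all three values sit where the limit of > 20000 nM in this assay, at which 3 of the 3 values shown sit, places them.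

The step from compound 3 to the not yet measured compound 4, `Nc1cc(C(=O)O)ccc1NC(=O)c1ccc(CNc2nccc(-c3cccnc3)n2)cc1`, is described by a group of 10 heavy atoms (7 carbon, 1 nitrogen, 2 oxygen; one six-membered aromatic ring of carbon only) in place of a group of 11 heavy atoms (10 carbon, 1 nitrogen; 2 six-membered aromatic rings of carbon only), on an amide-type nitrogen. Among the measured compounds shown here, two measured steps touch the same region of the core. The step that the two limits leave unreadable from compound 1 to compound 2 and the step that the two limits leave unreadable from compound 1 to compound 3 are both unreadable, since each starts and ends at a limit, so no size in either direction can be taken from them for this assay. With nothing that reads as a gain at this position, the expected outcome is that compound 4 stays at or near the limit, and the expected step that the limit leaves unreadable from compound 3 to compound 4 is therefore not one that can be called a change beyond the scatter. For compound 4 the estimate in this assay is 30000 nM, with a range from 8000 nM to 100000 nM.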

Compound 4, half-maximal inhibitory concentration: > 20000 nM
Compound 4: a limit, no number (the forecaster's own chance of this, stated with the estimate: 75%); the middle value lies beyond the limit too.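

Compound 4, like compound 1, compound 2 and compound 3, gives only a limit and no number, so none of its steps from those three compounds can be read: the limit of > 20000 nM in this assay, at which 4 of the 4 values shown sit.

The compounds shown leave open how strongly any of them acts in this assay, and whether any change on the shared core would yield a readable value.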